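Methoxycarbonyl to ethoxycarbonyl on the shared core

The compounds below may be only part of what the source reports. "The series", "measured", "known", "first", "only" and "open" are said of these compounds alone.

In a functional assay on HepG2 cells (Homo sapiens) for antiproliferative activity, read by MTT assay, with a stated time of 48 h (on this read-out lower numbers stand for stronger inhibition of growth and higher numbers for weaker inhibition of growth), compound 1 `CCOC(=O)N1N=C(c2ccccc2)CC1c1cc(OC)c(OC)c(OC)c1` gives 5950 nM, compound 2 `CCOC(=O)N1N=C(c2cccc(OC)c2)CC1c1cc(OC)c(OC)c(OC)c1` gives 5820 nM and compound 3 `COC(=O)N1N=C(c2ccc(OC)cc2)CC1c1cc(OC)c(OC)c(OC)c1` gives 1710 nM, the lowest of the three numbers. Compound 4 `CCOC(=O)N1N=C(c2ccc(OC)cc2)CC1c1cc(OC)c(OC)c(OC)c1` differs from compound 3 by one change methyl in place of hydrogen on a saturated chain carbon bound to an oxygen next to a carbonyl group, turning methoxycarbonyl into ethoxycarbonyl. Going by the values given here, no measured step makes this change. The only one, a 1.0-fold lower number from compound 1 to compound 2 (0.01 log units; within the scatter), adds a methoxy on an aromatic carbon instead. Compound 1 at 5950 nM and compound 2 at 5820 nM both carry ethoxycarbonyl and sit higher, though they also differ from compound 3 elsewhere. A moderate rise is therefore expected, a 1.8-fold higher number from compound 3 to compound 4 (0.24 log units; within the scatter). Compound 4 is estimated at 3000 nM, with an expected range from 1300 nM to 6500 nM.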

Compound 4, concentration for 50% growth inhibition: 9400 nM
Beside the measured number, compound 4's estimate is 3.1-fold (0.50 log units) below it; the measured number lies above the stated range.
By their numbers in this assay, from the lowest: compound 3; then compounds 2, 1 and 4 (each within the scatter of the next).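

In this assay one added methyl on this saturated chain carbon, turning methoxycarbonyl into ethoxycarbonyl, gives a 5.5-fold higher number from compound 3 to compound 4 (0.74 log units; beyond the scatter) and so shows that this position responds to a very small change. With ethoxycarbonyl in place, changing 3-methoxyphenyl to 4-methoxyphenyl gives a 1.6-fold higher number from compound 2 to compound 4 (0.21 log units; within the scatter) and adding a methoxy on an aromatic carbon gives a 1.6-fold higher number from compound 1 to compound 4 (0.20 log units; within the scatter) as well. The low number of compound 3 therefore goes with 4-methoxyphenyl and methoxycarbonyl together, not with 4-methoxyphenyl alone.

No evidence here explains the step. Open, as far as these compounds go, is how a longer chain such as propoxycarbonyl, or a carboxylic acid in place of this group, would read on the shared core.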